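Ethoxy on a phenyl ring of a weak triazole thioether

A few compounds are considered here, and "the series" means these few. Any claim that something is new, unique, unknown or untested is made for them only; others in the source may bear on it.

For the measured compounds named here, compound 2 (`Sc1nnc(Sc2nnc(-c3ccccc3)n2-c2ccccc2)n1-c1ccccc1`) is the only compound with a number here: in a functional assay on MDA-MB-231 cells (Homo sapiens) for inhibition, read by MTT assay, with a stated time of 48 h (a lower number here means a stronger inhibitor, a higher number a weaker inhibitor), compound 2 gives 34600 nM, a weak result. Compound 1 (`CC(C)n1c(S)nnc1Sc1nnc(-c2ccccc2)n1-c1ccccc1`), a close relative, has no number in this assay; its entry reads "not determined" (no result reported). Compound 3 (`CCOc1ccc(-n2c(S)nnc2Sc2nnc(-c3ccccc3)n2-c2ccccc2)cc1`) differs from compound 2 in one place: ethoxy in place of hydrogen on an aromatic carbon. Going by the values given here, no pair of measured compounds shows what such a change does in this assay, so the direction is unknown. The expectation is therefore a step of a 1.2-fold lower number from compound 2 to compound 3 (0.06 log units; within the scatter) that stays within the usual scatter, with weak inhibition kept. Compound 3 is thus estimated at 30000 nM, with a range from 8000 nM to 100000 nM, and the first measurement will show whether that holds.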

Compound 3, half-maximal inhibitory concentration: 43900 nM
Compound 3: the middle estimate sits 1.5-fold (0.17 log units) below what was measured, and the stated range covers the measured number.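

In this assay, the step on swapping hydrogen for ethoxy on an aromatic carbon, para to a large group, is a 1.3-fold higher number from compound 2 to compound 3 (0.10 log units; within the scatter). For the compounds shown here, this is the first measured look at this position: a phenyl can carry this ethoxy, and the two compounds cannot be told apart, with both remaining weak inhibitors. Nothing available explains this outcome.

A single change at a single position cannot show whether this ring is insensitive to substitution in general, or whether another group placed there, such as an amine, a carboxylic acid or a longer chain like butoxy, would shift the number beyond the scatter. Going by these compounds, compound 1 offers no help, since it has no number in this assay, so the effect of an isopropyl group in place of this phenyl also remains open.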